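One pyridine swap, tested on a second core

The source may report more compounds than this note shows. Statements on the series, on what has been measured and on what is new or still open speak of the compounds shown alone.

Compound 1 `Cn1cc(C2CC(c3ccccc3)=NN2C(=O)c2cccnc2)c2ccccc21` and compound 2 `Cn1cc(C2CC(c3ccccc3)=NN2C(=O)c2ccncc2)c2ccccc21` share one core and differ only in pyridin-4-yl in place of pyridin-3-yl on a carbonyl carbon. In a functional assay on A549 cells (Homo sapiens) for inhibition, read by MTT assay, with a stated time of 48 h (a lower number here means a stronger inhibitor of growth, a higher number a weaker inhibitor of growth), compound 1 reaches only a limit, > 10000 nM. Compound 2 gives 990 nM in this assay. The step of an at least 10-fold lower number from compound 1 to compound 2 (1.00 log units; beyond the scatter) is therefore known only at its lower end, resting on (the limit of > 10000 nM in this assay, at which 1 of the 3 values shown sits). Compound 3 `COc1ccc(C2=NN(C(=O)c3cccnc3)C(c3cn(C)c4ccc(Br)cc34)C2)cc1OC` carries a different core; how that core differs from the core of compound 1 is not broken down here. In this assay compound 3 gives 2380 nM. Compound 4 `COc1ccc(C2=NN(C(=O)c3ccncc3)C(c3cn(C)c4ccc(Br)cc34)C2)cc1OC` differs from compound 3 by pyridin-4-yl in place of pyridin-3-yl on a carbonyl carbon, the same change at the same place. For compound 4 a drop of about a 6.0-fold lower number from compound 3 to compound 4 (0.77 log units; beyond the scatter) is expected, a cautious reading of the earlier step, which is known only as a lower bound and was seen on another core. Compound 4 is thus estimated at 400 nM in this assay.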

Compound 4, concentration for 50% growth inhibition: 4250 nM
Compound 4: middle estimate off by 11-fold (1.03 log units), on the low side, and the stated range ends below it.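

On the second core, the same swap gives a 1.8-fold higher number from compound 3 to compound 4 (0.25 log units; within the scatter) in this assay and so produces no clear difference in growth inhibition. The benefit seen on the first core therefore did not carry over to the core of compound 3, showing that this change cannot be assumed to act alike on both cores: the same change on two cores in this assay, an at least 10-fold lower number (1.00 log units; beyond the scatter) from compound 1 to compound 2 and a 1.8-fold higher number (0.25 log units; within the scatter) from compound 3 to compound 4, at least 18-fold (1.25 log units) apart, beyond the scatter of two such steps. This does not show why the cores behave differently or how large the first step truly is, as compound 1 reaches only a limit: the limit of > 10000 nM in this assay, at which 1 of the 4 values shown sits.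

The compounds shown leave open which part of the core difference separates the two steps. They also leave open how a plain phenyl group or an amine-bearing pyridine on the carbonyl carbon would behave in this assay.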